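A few compounds are considered here, and "the series" means these few. Any claim that something is new, unique, unknown or untested is made for them only; others in the source may bear on it.

Measured so far in a functional assay on DU-145 cells (Homo sapiens) for cytotoxicity, read by MTT assay, with a stated time of 48 h; a lower number here means a stronger inhibitor, a higher number a weaker inhibitor:
compound 1 `CC(C)=CCC/C(C)=C/CC/C(C)=C/CC[C@@H]1[C@@]2(C)CCC(=O)C(C)(C)[C@@H]2CC[C@@]1(C)O`: 13200 nM
compound 2 `CC(C)=CCC/C(C)=C/CC/C(C)=C/CC[C@@H]1[C@@]2(C)CC/C(=N\OCc3cn(-c4ccccc4)nn3)C(C)(C)[C@@H]2CC[C@@]1(C)O`: 8830 nM
compound 3 `CC(C)=CCC/C(C)=C/CC/C(C)=C/CC[C@@H]1[C@@]2(C)CC/C(=N\OCc3cn(-c4ccc(Cl)cc4)nn3)C(C)(C)[C@@H]2CC[C@@]1(C)O`: 16200 nM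

Compound 3 gives the highest number of the three in this assay, yet its gap to compound 1 and its gap to compound 2 both lie within the scatter, so none of the three is set apart from the others. Going by the values given here, the only step made by a single change is a 1.8-fold higher number from compound 2 to compound 3 (0.26 log units; within the scatter), itself within the scatter.

Compound 4 `CC(C)=CCC/C(C)=C/CC/C(C)=C/CC[C@@H]1[C@@]2(C)CC/C(=N\OCc3cn(-c4ccccc4C#N)nn3)C(C)(C)[C@@H]2CC[C@@]1(C)O` carries 2-cyanophenyl in place of 4-chlorophenyl on an aromatic nitrogen. Among the compounds with values here, the one measured step that bears on this change is the exchange on the same aromatic ring, a 1.8-fold higher number from compound 2 to compound 3 (0.26 log units; within the scatter), which did not move the number beyond the scatter; no measured step covers a nitrile or a 2-cyanophenyl, so nothing points in either direction. The expectation for compound 4 in this assay is therefore no step beyond the scatter, a 1.2-fold lower number from compound 3 to compound 4 (0.10 log units; within the scatter). Compound 4 is estimated at 13000 nM, with a range of 5000 nM to 35000 nM.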

Compound 4, half-maximal inhibitory concentration: 25100 nM
For compound 4 the middle estimate is 1.9-fold (0.29 log units) below the measured one; low and high end bracket the measured number.
By their numbers in this assay, from the lowest: compounds 2, 1, 3 and 4 (each within the scatter of the next, the first and the last beyond it).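

In this assay, exchanging 4-chlorophenyl for 2-cyanophenyl on the aromatic nitrogen gives a step that stays within the scatter (a 1.5-fold higher number from compound 3 to compound 4 (0.19 log units; within the scatter)). Going by these compounds alone, measured against the unsubstituted phenyl, however, the nitrile gives the only step between compounds differing in one place that lies beyond the scatter (a 2.8-fold higher number from compound 2 to compound 4 (0.45 log units; beyond the scatter)), whereas the chloro step did not (a 1.8-fold higher number from compound 2 to compound 3 (0.26 log units; within the scatter)), so a substituent on this phenyl can raise the number modestly. No evidence at hand accounts for this step.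

The compounds shown do not separate the effect of the nitrile from that of its place on the ring. Going by these compounds, whether the number moves further, or falls below that of compound 2, with an amine or a carboxylic acid on this phenyl remains open.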